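This account rests on a few compounds, and the source may have more. Where it says the series, first, only, none or still open, it means among the compounds named here.

Measured so far:
- compound 1, `CC1(C)C2CC1[C@]1(C)OB([C@H](CCCN=C(N)N)NC(=O)c3ccc(-c4ccccc4)c(N)c3)O[C@@H]1C2`: 4.7 nM in an assay on isolated protein for inhibition of serine protease 1 (Homo sapiens); a higher number here means a weaker inhibitor, a lower number a stronger inhibitor
- compound 2, `Cc1cc(-c2ccccc2)ccc1C(=O)N[C@@H](CCCN=C(N)N)B1O[C@@H]2CC3CC(C3(C)C)[C@]2(C)O1`: 4.2 nM in this assay

Compound 1 gives the higher of the two numbers in this assay, but its gap to compound 2 is within the scatter, so the two measured compounds cannot be told apart on potency. Going by the values given here, no step between measured compounds that differ in one place is available, and nothing measured bears on a change at the position in question.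

The unmeasured compound 3, `CC1(C)C2CC1[C@]1(C)OB([C@H](CCCN=C(N)N)NC(=O)c3ccc(-c4ccccc4)c([N+](=O)[O-])c3)O[C@@H]1C2`, differs from compound 1 as follows: nitro in place of amino on an aromatic carbon

Among the compounds with values here, with no measured step to go on, the expectation for this assay rests on compound 1 alone, at 4.7 nM, and is for no step beyond the scatter, with a slight lean toward a weaker inhibitor. For compound 3 the estimated step is a 1.5-fold higher number from compound 1 to compound 3 (0.17 log units; within the scatter). Compound 3 is therefore expected to give about 7 nM, within a range of 1.5 nM to 30 nM.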

Compound 3, inhibition constant: 4.8 nM
Compound 3: the middle estimate sits 1.5-fold (0.16 log units) above what was measured; low and high end bracket the measured number.
By their numbers in this assay, from the lowest: compounds 2, 1 and 3 (each within the scatter of the next).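

In this assay, going by these compounds alone, nitro in place of amino on the aromatic carbon ortho to a phenyl group gives a 1.0-fold higher number from compound 1 to compound 3 (0.01 log units; within the scatter), the first step that can be read at this position, and it lies within the scatter. For this pair, the hydrogen-bond donor of amino can go and the larger nitro can enter with no change that can be told from scatter. Nothing available explains this result.

Still open, from the compounds shown here alone, is whether this position stays as undemanding with a carboxylic acid, a dimethylamino group or a methoxy group on the same carbon, or with hydrogen alone. Also open, going by these compounds, is whether the match between amino and nitro on the core of compound 1 extends to any read-out beyond this assay.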